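Swapping the amine on the thiocarbonyl carbon

This account rests on a few compounds, and the source may have more. Where it says the series, first, only, none or still open, it means among the compounds named here.

Measured compounds and their results in a functional assay on A-375 cells (Homo sapiens) for antiproliferative activity, read by CCK-8 assay, with a stated time of 72 h, tested at 8 uM; on this read-out lower numbers stand for a weaker effect and higher numbers for a stronger effect at the one concentration tested:
Compound 1 `CCN(Cc1ccncc1)C(=S)SCc1ccc(C(=O)Nc2ccccc2N)cc1`: 86.2%
Compound 2 `Nc1ccccc1NC(=O)c1ccc(CSC(=S)N2CCN(Cc3ccncc3)CC2)cc1`: 89.5%
Compound 3 `Nc1ccccc1NC(=O)c1ccc(CSC(=S)N2CCN(c3ccccc3F)CC2)cc1`: 79.5%

All three share one core and differ only in the amine attached to the thiocarbonyl carbon. Compound 1 sits within the usual scatter of both compound 2 and compound 3, so no ordering among them can be claimed. Among the measured compounds shown here, the only single-point step measured, a number 10 percentage points lower from compound 2 to compound 3 (within the scatter), exchanged a pyridine-bearing group for a fluorinated phenyl ring and stayed within the scatter.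

Compound 4 `Nc1ccccc1NC(=O)c1ccc(CSC(=S)N2CCc3cc(Cl)ccc32)cc1` is the unmeasured analogue of compound 1, where (5-chloro-2,3-dihydro-1H-indol-1-yl in place of ethyl((pyridin-4-yl)methyl)amino on a thiocarbonyl carbon). That step to compound 3 is the closest guide, and it suggests little change. Compound 4 is therefore expected to give 80%, between 65% and 92%, an estimated a number 6.2 percentage points lower from compound 1 to compound 4 (within the scatter) that need not exceed the scatter.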

Compound 4, a percentage reported as inhibition, at one concentration (the size of the read-out at that concentration, not a potency): 82.3%
The estimate for compound 4 lay 2.3 percentage points below the measured number; low and high end bracket the measured number.
By their numbers in this assay, from the lowest: compounds 3, 4, 1 and 2 (each within the scatter of the next).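

In this assay, a number 3.9 percentage points lower from compound 1 to compound 4 (within the scatter) shows that an open-chain amine carrying a pyridine ring and 5-chloro-2,3-dihydro-1H-indol-1-yl can stand on the thiocarbonyl carbon with numbers that stay within the scatter. Compound 3 had kept a ring amine on this carbon, whereas this change brings a chlorine-bearing group and removes the hydrogen-bond acceptor of the leaving group. Nothing measured on these compounds gives a reason for this result. As far as these compounds go, whether a dimethylamino group, or an amine bearing a carboxylic acid, on this carbon would move the number beyond the scatter remains open.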